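From 3-Methylbenzyl to 2-Methylbenzyl

A few compounds are considered here, and "the series" means these few. Any claim that something is new, unique, unknown or untested is made for them only; others in the source may bear on it.

In a functional assay on BGC-823 cells (Homo sapiens) for inhibition, read by MTT assay, with a stated time of 72 h (a lower number here means a stronger inhibitor, a higher number a weaker inhibitor), compound 1 (`O=C1/C(=C\c2ccccc2)c2c(ncn2COCc2ccccc2)CCN1Cc1ccc(F)cc1`) gives 72900 nM, compound 2 (`Cc1cc(C)cc(CN2CCc3ncn(COCc4ccccc4)c3/C(=C/c3ccccc3)C2=O)c1`) gives 52600 nM and compound 3 (`Cc1cccc(CN2CCc3ncn(COCc4ccccc4)c3/C(=C/c3ccccc3)C2=O)c1`) gives 14600 nM, the lowest of the three numbers. Compound 4 (`Cc1ccccc1CN1CCc2ncn(COCc3ccccc3)c2/C(=C/c2ccccc2)C1=O`) has 2-methylphenyl in place of 3-methylphenyl on a saturated chain carbon bound to an amide-type nitrogen in a ring. Three measured steps change the group at this place. Replacing 4-fluorophenyl with 3-methylphenyl brought a 5.0-fold lower number from compound 1 to compound 3 (0.70 log units; beyond the scatter), and replacing it with 3,5-dimethylphenyl brought a 1.4-fold lower number from compound 1 to compound 2 (0.14 log units; within the scatter). Hydrogen in place of methyl on an aromatic carbon brought a 3.6-fold lower number from compound 2 to compound 3 (0.56 log units; beyond the scatter). Among the measured compounds shown here, none of these steps exchanges 3-methylphenyl for 2-methylphenyl, so they show only that this group can shift the number modestly. Compound 3 at 14600 nM stands below both other compounds, so a small move toward a higher number is expected, an estimated 2.1-fold higher number from compound 3 to compound 4 (0.31 log units; beyond the scatter). The estimated value for compound 4 is 30000 nM, with an expected range of 9000 nM to 75000 nM.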

Compound 4, half-maximal inhibitory concentration: 31300 nM
Compound 4: the middle estimate sits 1.0-fold (0.02 log units) below what was measured, within the range that was stated.
By their numbers in this assay, from the lowest: compound 3; then compounds 4, 2 and 1 (each within the scatter of the next, the first and the last beyond it).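

In this assay, among the compounds shown here, (this assay), moving the one methyl group from 3-methylphenyl to 2-methylphenyl, with the same atoms joined differently, changes the number beyond the scatter (a 2.1-fold higher number from compound 3 to compound 4 (0.33 log units; beyond the scatter)), so at this place the position of the methyl matters as well as its presence. Compound 4 also stands beyond the scatter from the 4-fluorophenyl compound (a 2.3-fold lower number from compound 1 to compound 4 (0.37 log units; beyond the scatter)), while its step from the 3,5-dimethylphenyl compound stays within the scatter (a 1.7-fold lower number from compound 2 to compound 4 (0.23 log units; within the scatter)). Nothing available here accounts for these differences.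

The compounds shown leave open how an unsubstituted phenyl, a methoxyphenyl or an aminophenyl at this place would compare with compound 3. They also leave open whether moving a group other than methyl around the ring would matter as much.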